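Removing one methyl from the lower-valued compound

This account rests on a few compounds, and the source may have more. Where it says the series, first, only, none or still open, it means among the compounds named here.

For the measured compounds named here, in a functional assay on A2780 cells (Homo sapiens) for antiproliferative activity, read by MTT assay, with a stated time of 48 h (a higher number here means a weaker inhibitor, a lower number a stronger inhibitor), compound 1 (`COc1ccc2c(/C=C(\C)C(=O)c3cc(OC)c(OC)c([Se]C)c3)cn(C)c2c1`) gives 26 nM and holds the lower of the two numbers measured so far. Compound 2 (`COc1ccc2c(/C=C/C(=O)c3cc(OC)c(OC)c(SC)c3)cn(C)c2c1`) gives 145 nM as its value, a gap beyond the usual scatter, although these two compounds differ in more than one place and the gap cannot be tied to any single change. Compound 3 (`COc1ccc2c(/C=C(\C)C(=O)c3cc(OC)c(OC)c([Se]C)c3)c[nH]c2c1`) keeps the core of compound 1 and alters one site (hydrogen in place of methyl on an aromatic nitrogen): hydrogen in place of methyl on an aromatic nitrogen. Going by the values given here, no measured pair shows this change alone, so the expectation is loose: a modest rise in this assay is expected, perhaps one that stays within the scatter. The expected step of a 1.7-fold higher number from compound 1 to compound 3 (0.24 log units; within the scatter) is an estimate only. Compound 3 is estimated at 45 nM with 12 nM to 170 nM as its expected span.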

Compound 3, half-maximal inhibitory concentration: 18 nM
Compound 3: middle estimate off by 2.5-fold (0.40 log units), on the high side; the range from low to high includes it.
By their numbers in this assay, from the lowest: compounds 3 and 1 (each within the scatter of the next); then compound 2.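

For the compounds shown here, compound 3 gives the first comparison in which only one site changes: with hydrogen in place of methyl on an aromatic nitrogen, this assay shows a 1.4-fold lower number from compound 1 to compound 3 (0.16 log units; within the scatter) and this step stays within the scatter. The methyl on this nitrogen is therefore not required for the activity of compound 1 in this assay, and the free nitrogen-hydrogen form is tolerated on this core. No measurement is available that would explain this result.

On these data alone, it remains open how a group larger than methyl on this nitrogen, such as an ethyl, a longer chain or an acetyl, would read in this assay. As far as these compounds go, it is also open whether the same change would give a similar step on compound 2, which differs from compound 1 in more than one place.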